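The compounds below may be only part of what the source reports. "The series", "measured", "known", "first", "only" and "open" are said of these compounds alone.

Measured so far: compound 1 `C[C@@H](NC(=O)Nc1ccccc1Cl)c1ccccc1` with 101%, compound 2 `C[C@H](NC(=O)Nc1cccc(Cl)c1)c1ccccc1` with 103%, and compound 3 `C[C@H](NC(=O)Nc1cccc(Cl)c1Cl)c1ccccc1` with 100%, all in an ADME assay on the whole organism with Oryza sativa as the target, tested at 0.1 uM; a higher number here means a weaker effect of the compound at the concentration tested, a lower number a stronger effect.

Compound 1 and compound 2 have the same atoms joined differently; the difference between the two cores is not broken down here. Compound 3 arises from compound 2 by chloro in place of hydrogen on an aromatic carbon and this gave a number 3 percentage points lower from compound 2 to compound 3 (within the scatter). Compound 4 `C[C@@H](NC(=O)Nc1ccc(Cl)cc1Cl)c1ccccc1`, not yet measured, arises from compound 1 by chloro in place of hydrogen on an aromatic carbon. Among the measured compounds shown here, this is the same kind of change as the one from compound 2 to compound 3, though not the same: in compound 3 the entering chloro sits ortho to a chloro group and ortho to a large group, in compound 4 meta to a chloro group and para to a large group. Since compound 3 gave 100% after that step, compound 4 is expected to give 100% in this assay, a step of a number 1 percentage points lower from compound 1 to compound 4 (within the scatter), between 92% and 108%.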

Compound 4, a percentage reported as activity, at one concentration (the size of the read-out at that concentration, not a potency): 101%
Compound 4: middle estimate off by 1 percentage points, on the low side; low and high end bracket the measured number.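

In this assay, chloro in place of hydrogen on an aromatic carbon gave no change at the digits printed from compound 1 to compound 4 (within the scatter). Set beside the earlier step, the change carried from one core to the other without a difference between the two steps: the same change on two cores in this assay, a number 3 percentage points lower (within the scatter) from compound 2 to compound 3 and no change at the digits printed (within the scatter) from compound 1 to compound 4, 3 percentage points apart, within the scatter of two such steps. This shows that the change left the number within the scatter on both cores, but it does not show that the change has any effect, and with the entering chloro placed differently on each core, it cannot separate the core from the position.

The compounds shown leave open whether a group other than chloro on the aromatic ring, such as a nitrile, a methoxy group, an amine or a carboxylic acid, would move the number beyond the scatter in this assay.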